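Carbonate alkyl variation and solubility in a purine series

This account rests on a few compounds, and the source may have more. Where it says the series, first, only, none or still open, it means among the compounds named here.

Measured compounds:
compound 1 `CCCCOC(=O)OCC(CO)CCn1cnc2cnc(N)nc21` gives 15000 ug/mL
compound 2 `CCCOC(=O)OCC(CO)CCn1cnc2cnc(N)nc21` gives 68000 ug/mL

Compound 2 stands highest of the two numbers in a physicochemical assay for solubility, read by spectrophotometry, at 20 degrees C; on this read-out lower numbers stand for lower solubility and higher numbers for higher solubility; its nearest neighbour is compound 1, and the step between them is a 4.5-fold higher number from compound 1 to compound 2 (0.66 log units; beyond the scatter), beyond the scatter and modest in size. That step is the only one measured so far, and it consists of hydrogen in place of methyl on a saturated chain carbon, three bonds along the chain from an oxygen next to a carbonyl group.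

Compound 3 `CC(C)OC(=O)OCC(CO)CCn1cnc2cnc(N)nc21` has not been measured. It differs from compound 2 by isopropyl in place of propyl on an oxygen next to a carbonyl group. The two compounds have the same atoms, joined differently, so the measured step, which removed one carbon, bears on the present change only loosely: it shows that the carbonate alkyl group does move the read-out, but gives no direct guide to a rearrangement that keeps the count of atoms.

Among the compounds with values here, with no closer precedent, compound 3 is expected to lie near compound 2, and the estimated step of a 1.2-fold higher number from compound 2 to compound 3 (0.07 log units; within the scatter) is within the scatter or at most a small rise. Compound 3 is estimated at 80000 ug/mL, with a range from 30000 ug/mL to 180000 ug/mL.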

Compound 3, solubility: 139000 ug/mL
The estimate for compound 3 lay 1.7-fold (0.24 log units) below the measured number; the range from low to high includes it.
By their numbers in this assay, from the lowest: compound 1; then compound 2; then compound 3.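

In this assay, the carbonate alkyl group responds to rearrangement as well as to chain length: isopropyl in place of propyl on an oxygen next to a carbonyl group, with the same atoms joined differently, gives a 2.0-fold higher number from compound 2 to compound 3 (0.31 log units; beyond the scatter) and so moves the read-out without any change in the count of atoms. Isopropyl in place of butyl on the same oxygen gives a 9.3-fold higher number from compound 1 to compound 3 (0.97 log units; beyond the scatter) as the largest step among the three compounds, and the order of butyl, then propyl, then isopropyl has no exception within this set, though it rests on these compounds alone. No accompanying measurement bears on why the branched group reads higher than the straight chain.

The compounds shown leave open whether the rise continues with shorter groups such as ethyl or methyl, and whether more heavily branched or ring-bearing groups such as tert-butyl or cyclopropyl extend it or reverse it. They also leave open how a carboxylic acid or an amine carried on the alkyl group would read in this assay, and whether the branched-over-straight order would hold for a longer chain such as pentyl.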